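Switching a nitrobenzyl for a chlorobenzyl group

A few compounds are considered here, and "the series" means these few. Any claim that something is new, unique, unknown or untested is made for them only; others in the source may bear on it.

Compound 1 `COC(=O)[C@H](CCSC)NC(=O)c1ccc(NCc2cncn2Cc2cccc([N+](=O)[O-])c2)cc1-c1ccccc1` gives only a limit, > 10 uM, in a functional assay on NIH3T3 cells (Mus musculus); a higher number here means that more compound is needed for the effect, a lower number that less compound is needed.
Compound 2 `CSCC[C@H](NC(=O)c1ccc(NCc2cncn2Cc2cccc(C#N)c2)cc1-c1ccccc1)C(=O)O` gives only a limit, > 10 uM, in this assay.
Compound 3 `COC(=O)[C@H](CCSC)NC(=O)c1ccc(CNCc2cncn2Cc2ccc(C#N)cc2)cc1-c1ccccc1C` gives only a limit, > 10 uM, in this assay.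

None of the three measured compounds yields a number in this assay; each stops at the limit of > 10 uM in this assay, at which 3 of the 3 values shown sit. Compound 1 therefore stands at that limit, and nothing in the three values separates it from compound 2 or compound 3.

Compound 4 `COC(=O)[C@H](CCSC)NC(=O)c1ccc(NCc2cncn2Cc2ccccc2Cl)cc1-c1ccccc1` shares the core of compound 1 and differs in one place: 2-chlorophenyl in place of 3-nitrophenyl on a saturated chain carbon bound to an aromatic nitrogen. Going by the values given here, no step between measured compounds is available that would show how this exchange moves the read-out in this assay, so the expectation rests on where compound 1 sits alone.

Compound 4 is expected to remain at or near the limit, with an estimated value of 15 uM and a range from 4 uM to 60 uM. That expectation amounts to a step that the limit leaves unreadable from compound 1 to compound 4, which is not beyond the scatter.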

Compound 4, concentration for half-maximal effect: > 10 uM
Compound 4: only a limit was reported; the forecaster's own chance of this, stated with the estimate: 70%; the middle value is on the limit's open side.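

In this assay compound 4 gives > 10 uM, which is a limit and not a number. Compound 1 also stops at a limit, so no step can be read between compound 1 and compound 4. Whether any change to these structures would give a readable number stays open, with every value at the same point: the limit of > 10 uM in this assay, at which 4 of the 4 values shown sit.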